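A few compounds are considered here, and "the series" means these few. Any claim that something is new, unique, unknown or untested is made for them only; others in the source may bear on it.

Three compounds were measured in an ADME assay on MT4 cells (Homo sapiens) for cytotoxicity, read by MTT assay, with a stated time of 96 h; a lower number here means that less compound is tolerated, a higher number that more compound is tolerated:
compound 1 `COc1ccc(-c2nc3cc(Cl)c(Cl)cc3[nH]2)c([N+](=O)[O-])c1`, 2000 nM;
compound 2 `COc1ccc(-c2nc3cc(Cl)c(Cl)cc3[nH]2)c(N)c1`, 3000 nM;
compound 3 `COc1ccc(-c2nc3cc(C(F)(F)F)ccc3[nH]2)c([N+](=O)[O-])c1`, 85000 nM.

Compound 1 and compound 2 share one core and differ in a single place: amino in place of nitro on an aromatic carbon. In this assay this change gave a 1.5-fold higher number from compound 1 to compound 2 (0.18 log units; within the scatter), a step that stays within the scatter, so the two values cannot be told apart. Compound 3 carries a different core; how that core differs from the core of compound 1 is not broken down here. In this assay compound 3 stands highest of the three, and its distance from both compound 1 and compound 2 lies beyond the scatter.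

Compound 4 `COc1ccc(-c2nc3cc(C(F)(F)F)ccc3[nH]2)c(N)c1` has not yet been measured. It stands to compound 3 as compound 2 stands to compound 1: amino in place of nitro on an aromatic carbon. The surroundings of the change are described in the same words for both pairs, so it is the same change, made on the core of compound 3 instead of the core of compound 1. Among the measured compounds shown here, the one guide to its size is the measured pair. For compound 4 in this assay the expected step is a 1.2-fold higher number from compound 3 to compound 4 (0.07 log units; within the scatter). This expectation rests on a 1.5-fold higher number from compound 1 to compound 2 (0.18 log units; within the scatter), which was within the scatter, and on the value of compound 3, 85000 nM. Compound 4 is therefore expected to give about 100000 nM in this assay, with a likely range from 40000 nM to 250000 nM.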

Compound 4, half-maximal cytotoxic concentration: 5000 nM
Estimate against measurement, compound 4: 20-fold (1.30 log units) above; measured number outside the range, below it.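

In this assay, amino in place of nitro on an aromatic carbon gave a 17-fold lower number from compound 3 to compound 4 (1.23 log units; beyond the scatter), so on the core of compound 3 the change is large, whereas on the core of compound 1 its effect could not be told from the scatter. The same change therefore did not carry over in size from one core to the other: the same change on two cores in this assay, a 1.5-fold higher number (0.18 log units; within the scatter) from compound 1 to compound 2 and a 17-fold lower number (1.23 log units; beyond the scatter) from compound 3 to compound 4, 26-fold (1.41 log units) apart, beyond the scatter of two such steps. This shows that, in this series, a step measured on one core is no safe guide to the same step on another, but two pairs do not show which feature of the cores sets the gap, nor how the change would behave on any further core.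

The compounds shown leave open whether a nitrile or a carboxylic acid on the same aromatic carbon would follow the nitro or the amino compounds on each core. They also leave open whether the gap between the two pairs would persist on a core carrying a single chlorine, or a methyl in place of trifluoromethyl, and so which part of the core difference matters.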